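Thiazole in Place of Benzimidazole: Solubility Outlook

This account rests on a few compounds, and the source may have more. Where it says the series, first, only, none or still open, it means among the compounds named here.

Compound 1 `Cc1cc(C)c(-c2ncc[nH]2)cc1NC(=O)c1ccc(OCc2ccccn2)cc1` carries a 1H-imidazol-2-yl group on an aromatic carbon of the shared core; in a physicochemical assay for solubility, at pH 7.4 (a higher number here means a more soluble compound, a lower number a less soluble compound), compound 1 gives 2000 nM. Compound 2 `Cc1cc(C)c(-c2nc3ccccc3[nH]2)cc1NC(=O)c1ccc(OCc2ccccn2)cc1` differs from it in one place, with 1H-benzimidazol-2-yl in place of 1H-imidazol-2-yl on that aromatic carbon. In this assay compound 2 reaches only a limit of the assay, < 1000 nM. The step of an at least 2.0-fold lower number from compound 1 to compound 2 (0.30 log units; that floor lies within the scatter) is accordingly known only as a floor, and the limit of < 1000 nM in this assay, at which 1 of the 2 values shown sits, notes that one of the two values sits at that limit. Compound 2 therefore stands at the lowest reportable point of the assay, with no exact number to its name.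

Compound 3 `Cc1csc(-c2cc(NC(=O)c3ccc(OCc4ccccn4)cc3)c(C)cc2C)n1` has not yet been measured in this assay. The change from compound 2 is 4-methyl-1,3-thiazol-2-yl in place of 1H-benzimidazol-2-yl on an aromatic carbon. Among the measured compounds shown here, the single measured step, from compound 1 to compound 2, enlarged the group and lowered solubility by an amount whose floor lies within the scatter, so it bears on this reverse-direction change only loosely. The step expected is an at least 1.2-fold higher number from compound 2 to compound 3 (0.07 log units; that floor lies within the scatter). For compound 3 the estimate in this assay is 1200 nM, within a range from 400 nM to 4000 nM.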

Compound 3, solubility: < 1000 nM
Compound 3 was reported as a limit (the forecaster's own chance of this, stated with the estimate: 35%); middle value at least 1.2-fold (0.07 log units) away from the limit.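

In this assay compound 3 also ends at a limit of the assay, not at a number, so this position now has two different groups at that same limit: the limit of < 1000 nM in this assay, at which 2 of the 3 values shown sit. With both values at a limit, the step between compound 2 and compound 3 cannot be read, and the data cannot tell whether 4-methyl-1,3-thiazol-2-yl or 1H-benzimidazol-2-yl gives the higher number on this aromatic carbon, ortho to a methyl group and para to another. Among the compounds shown here, what can be read is the comparison with 1H-imidazol-2-yl, where 4-methyl-1,3-thiazol-2-yl gives an at least 2.0-fold lower number from compound 1 to compound 3 (0.30 log units; that floor lies within the scatter), the same floor as the earlier at least 2.0-fold lower number from compound 1 to compound 2 (0.30 log units; that floor lies within the scatter), which leaves compound 1 as the only compound here with an exact value.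

From the compounds shown here alone, how far compound 2 and compound 3 lie beyond the limit, and whether they differ at all, remains open. Also open, going by these compounds, is whether a carboxylic acid or an aminomethyl group on this aromatic carbon would give a value that can be read as a number in this assay, and how that value would compare with compound 1.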